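Alkyne-linked aryl variants: efficacy notes on the series

A few compounds are considered here, and "the series" means these few. Any claim that something is new, unique, unknown or untested is made for them only; others in the source may bear on it.

Measured in an ADME assay on HEK293 cells for agonist activity at metabotropic glutamate receptor 5 (Rattus norvegicus), read by fluorescence and calcium flux; on this read-out lower numbers stand for smaller maximal responses and higher numbers for larger maximal responses:
compound 1 `C[C@@H](NC(=O)c1ccc(C#Cc2ccccc2F)cn1)C(C)(C)O` gives 29.6%
compound 2 `C[C@@H](NC(=O)c1ccc(C#Cc2cc(F)cc(F)c2)cn1)C(C)(C)O` gives 37.9%
compound 3 `C[C@@H](NC(=O)c1ccc(C#Cc2cccnc2)cn1)C(C)(C)O` gives 25.9%

Compound 3 stands lowest of the three numbers shown. Its nearest neighbour is compound 1, with a number 3.7 percentage points lower from compound 1 to compound 3 (within the scatter); its furthest is compound 2, with a number 12 percentage points lower from compound 2 to compound 3 (beyond the scatter).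

Compound 4 `C[C@@H](NC(=O)c1ccc(C#Cc2ccncc2)cn1)C(C)(C)O` differs from compound 3 by pyridin-4-yl in place of pyridin-3-yl on a triple-bonded carbon. For the measured compounds named here, no measured step exchanges one pyridinyl for another, so the steps that bear on it are the other exchanges of the group on that triple-bonded carbon: a number 8.3 percentage points higher from compound 1 to compound 2 (within the scatter) and a number 3.7 percentage points lower from compound 1 to compound 3 (within the scatter), both within the scatter, and a number 12 percentage points lower from compound 2 to compound 3 (beyond the scatter), modest. A step of at most that order is therefore expected in this assay, most likely none beyond the scatter. Compound 4 is estimated at 27%, range 13% to 42%, which corresponds to an expected step of a number 1.1 percentage points higher from compound 3 to compound 4 (within the scatter).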

Compound 4, largest response reached (reported as efficacy), in percent of the reference or control that the assay uses: 22.4%
The estimate for compound 4 lay 4.6 percentage points above the measured number; measured number inside the range.
By their numbers in this assay, from the lowest: compounds 4, 3, 1 and 2 (each within the scatter of the next, the first and the last beyond it).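

In this assay, for the compounds shown here, the first exchange of one pyridinyl for another, pyridin-4-yl in place of pyridin-3-yl on the triple-bonded carbon, gives a number 3.5 percentage points lower from compound 3 to compound 4 (within the scatter), so the two isomers are not separated on this read-out. The fluorinated comparisons for pyridin-4-yl give a number 15.5 percentage points lower from compound 2 to compound 4 (beyond the scatter) and a number 7.2 percentage points lower from compound 1 to compound 4 (within the scatter), so only the 3,5-difluorophenyl comparison exceeds the scatter. No available evidence bears on the reason for these numbers. As far as these compounds go, it remains open whether pyridin-2-yl or an aminophenyl on that triple-bonded carbon would match compound 2 or exceed it.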